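The compounds below may be only part of what the source reports. "The series", "measured", "known", "first", "only" and "open" are said of these compounds alone.

Working notes on the amide series built on the shared core of compound 1 `COc1ccc(OC)c(-c2cc(-c3ccc(C(=O)N4CCCCC4)s3)on2)c1`, all read in a functional assay on PC-3 cells (Homo sapiens) for cytotoxicity, read by XTT assay, with a stated time of 72 h; on this read-out lower numbers stand for stronger inhibition and higher numbers for weaker inhibition. In this assay compound 1 gives > 30000 nM, which is a limit of the assay and not a number. Compound 2 `COc1ccc(OC)c(-c2cc(-c3ccc(C(=O)N(C)Cc4ccc(F)cc4)s3)on2)c1` in this assay gives > 30000 nM, again a limit. Compound 3 `COc1ccc(OC)c(-c2cc(-c3ccc(C(=O)NCC4CC4)s3)on2)c1` in this assay gives > 30000 nM, also a limit. Compound 3 thus stands at the same limit as compound 1 and compound 2, and no order among the three can be read. The steps a step that the two limits leave unreadable from compound 1 to compound 2, a step that the two limits leave unreadable from compound 1 to compound 3 and a step that the two limits leave unreadable from compound 2 to compound 3 remain unreadable because the limit of > 30000 nM in this assay, at which 3 of the 3 values shown sit, leaves nothing to compare.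

Compound 4 `COc1ccc(OC)c(-c2cc(-c3ccc(C(=O)N4CCC(C(F)(F)F)CC4)s3)on2)c1` differs from compound 3 by 4-(trifluoromethyl)piperidin-1-yl in place of (cyclopropylmethyl)amino on a carbonyl carbon. The measured steps that bear on this change are the three exchanges of the amide substituent on the carbonyl carbon, each of unreadable size, and none of them resolved a number in this assay. The step of a number no higher from compound 3 to compound 4 (the limit leaves the size open) is therefore expected to be none beyond the scatter, with a further limit the most probable outcome. Compound 4 is estimated at 30000 nM, within a range from 10000 nM to 100000 nM.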

Compound 4, half-maximal inhibitory concentration: > 30000 nM
Compound 4 ended at the assay's limit; the forecaster's own chance of this, stated with the estimate: 80%; the middle value lies on the limit itself.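

No step linking compound 4 with compound 1, compound 2 or compound 3 can be read in this assay, because the four compounds share one limit and nothing separates them: the limit of > 30000 nM in this assay, at which 4 of the 4 values shown sit.

The compounds shown leave open how these four rank and whether any amide substituent on the carbonyl carbon of the shared core gives a readable number in this assay.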